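The source may report more compounds than this note shows. Statements on the series, on what has been measured and on what is new or still open speak of the compounds shown alone.

Measured compounds:
- compound 1, `COc1nc(N)nc2c1c(-c1cc3ccccc3o1)cn2[C@@H]1O[C@H](CO)[C@@H](O)[C@H]1O`: 22700 nM
- compound 2, `Nc1nc(N)c2c(-c3cc4ccccc4o3)cn([C@@H]3O[C@H](CO)[C@@H](O)[C@H]3O)c2n1`: 78500 nM
- compound 3, `CNc1ncnc2c1c(-c1ccco1)cn2[C@@H]1O[C@H](CO)[C@@H](O)[C@H]1O`: 90800 nM

All three values come from an ADME assay on MRC5 cells (Homo sapiens), read by MTT assay, with a stated time of 72 h; a lower number here means a stronger inhibitor, a higher number a weaker inhibitor. Among them compound 1 stands lowest; compound 2 lies a 3.5-fold higher number from compound 1 to compound 2 (0.54 log units; beyond the scatter) away, and compound 3 gives the highest number of the set, the gap to compound 1 being beyond the scatter.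

The unmeasured compound 4, `C#Cc1cn([C@@H]2O[C@H](CO)[C@@H](O)[C@H]2O)c2nc(N)nc(OC)c12`, differs from compound 1 by the change (ethynyl in place of 1-benzofuran-2-yl on an aromatic carbon). For the measured compounds named here, the only measured single-point step, a 3.5-fold higher number from compound 1 to compound 2 (0.54 log units; beyond the scatter), concerns the amino in place of methoxy on an aromatic carbon and does not touch the group exchanged here. Compound 3 carries a smaller furan-2-yl group together with a different amine, so its value against compound 1 gives only a loose hint that shedding the larger aromatic group goes with a higher number. On this thin basis, a modest rise beyond the scatter is expected for compound 4, a 2.4-fold higher number from compound 1 to compound 4 (0.38 log units; beyond the scatter).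

Compound 4 is therefore estimated at 55000 nM in this assay, within 20000 nM to 150000 nM.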

Compound 4, half-maximal inhibitory concentration: > 100000 nM
Compound 4 was reported as a limit; the forecaster's own chance of this, stated with the estimate: 30%; middle value at least 1.8-fold (0.25 log units) away from the limit.
By their numbers in this assay, from the lowest: compound 1; then compounds 2 and 3 (each within the scatter of the next). At a limit, above all of these: compound 4.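

In this assay compound 4 reads > 100000 nM, which is a limit of the assay and not a number. The exchange of 1-benzofuran-2-yl for ethynyl gives an at least 4.4-fold higher number from compound 1 to compound 4 (0.64 log units; beyond the scatter), so the group on this aromatic carbon of the five-membered aromatic ring matters for the read-out, and the step is open-ended on its upper side. For the compounds shown here, this is the first single-point step at this carbon, where the earlier step concerned only amino in place of methoxy.

Going by these compounds, how far compound 4 lies past its limit stays open, as does whether the same exchange gives a comparable step on the core of compound 2. Also open, on these data alone, is whether a phenyl ring, a propyl chain or an aminomethyl group on this carbon would fall nearer to compound 1 or to compound 4.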